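Short allyl ether in place of hydroxyalkyl chain

This account rests on a few compounds, and the source may have more. Where it says the series, first, only, none or still open, it means among the compounds named here.

Compound 1 `O=C(O)CCCCCCCCCCCCCCCOc1ccc2c(=O)c(-c3ccc(O)cc3)coc2c1` carries a long carboxy-terminated chain on the shared core. In an assay (Cricetulus griseus) for inhibition of aldehyde dehydrogenase, mitochondrial (Homo sapiens) (a higher number here means a weaker inhibitor, a lower number a stronger inhibitor), compound 1 gives only a limit, > 9000 nM; this is the limit of > 9000 nM in this assay, at which 1 of the 3 values shown sits. Compound 2 `O=c1c(-c2ccc(O)cc2)coc2cc(OCCCCCCCCCO)ccc12` gives 700 nM in this assay, and compound 3 `O=c1c(-c2ccc(O)cc2)coc2cc(OCCCCCCCCCCCCO)ccc12` gives 1700 nM. Of the two numbers shown, compound 2 stands lowest, with compound 3 nearest: a 2.4-fold higher number from compound 2 to compound 3 (0.39 log units; beyond the scatter). The steps from the carboxylic acid run an at least 12-fold lower number from compound 1 to compound 2 (1.10 log units; beyond the scatter) and an at least 5.2-fold lower number from compound 1 to compound 3 (0.72 log units; beyond the scatter).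

Compound 4 `C=CCOc1ccc2c(=O)c(-c3ccc(O)cc3)coc2c1` keeps the shared core and differs from compound 2 in one place: vinyl in place of 8-hydroxyoctyl on a saturated chain carbon bound to an oxygen on an aromatic ring. Among the compounds with values here, the steps that bear on it are those altering the chain end, where a hydroxy end gave the lowest numbers and the carboxy end only a limit, and the chain-length step from compound 2 to compound 3, which was modest and upward. Compound 4 loses the hydroxy end and most of the chain at once, a change beyond any measured step, so a modest rise in the number is expected rather than a fall. Compound 4 is estimated at 2500 nM in this assay, with a range from 700 nM to 9000 nM. The expected step is a 3.6-fold higher number from compound 2 to compound 4 (0.55 log units; beyond the scatter).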

Compound 4, half-maximal inhibitory concentration: 180 nM
Compound 4: middle estimate off by 14-fold (1.14 log units), on the high side; the measured number lies below the stated range.
By their numbers in this assay, from the lowest: compound 4; then compound 2; then compound 3. At a limit, above all of these: compound 1.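

In this assay, shortening the chain does not cost potency at this position: a 3.9-fold lower number from compound 2 to compound 4 (0.59 log units; beyond the scatter). Within the data shown here, neither 8-hydroxyoctyl nor a hydroxy chain end is therefore required for a low number on the shared core, whereas the earlier compounds compared only long chains with hydroxy or carboxy ends. Across compound 3, compound 2 and compound 4 the number falls as the chain shortens, but compound 4 also loses the hydroxy end and gains a double bond, so this order does not isolate chain length.

Open, going by these compounds, is which of the three changes carries the step: a saturated propyl ether on the shared core would test the double bond, and a 3-hydroxypropyl ether would test a short chain that keeps the hydroxy end. Nothing in the data shown accounts for the lower number of compound 4.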